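Compound 3 as a one-place variation on compound 1

A few compounds are considered here, and "the series" means these few. Any claim that something is new, unique, unknown or untested is made for them only; others in the source may bear on it.

Within the data shown here, compound 1 `COc1ccc(CN(C(=O)C(C)Br)c2cc(OC)c(OC)c(OC)c2)cc1O` is the only compound of this small set with a numerical result: in a functional assay on MGC-803 cells (Homo sapiens) for inhibition, read by MTT assay, with a stated time of 48 h (on this read-out lower numbers stand for stronger inhibition and higher numbers for weaker inhibition), compound 1 gives 120 nM. Compound 2 `COc1cc(NCc2ccc(Cl)cc2)cc(OC)c1OC` shares part of the core of compound 1 but carries no acyl group on its nitrogen. In this assay compound 2 reaches only a limit of the assay, > 80000 nM. Among the measured compounds shown here, of the two values shown, one therefore sits at the limit of > 80000 nM in this assay, at which 1 of the 2 values shown sits, and no step between measured compounds that differ in a single place is available. Compound 3 `COc1ccc(CN(C(=O)C[Se]C#N)c2cc(OC)c(OC)c(OC)c2)cc1O` has not yet been measured. It differs from compound 1 in one place: a group of 4 heavy atoms (2 carbon, 1 nitrogen, 1 selenium; no ring) in place of a group of 3 heavy atoms (2 carbon, 1 bromine; no ring), on a carbonyl carbon. For the measured compounds named here, with no measured step to lean on, the expected step of a 1.7-fold higher number from compound 1 to compound 3 (0.22 log units; within the scatter) is modest and not clearly beyond the scatter in either direction. Compound 3 is accordingly expected to give about 200 nM in this assay, within a range from 30 nM to 1500 nM.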

Compound 3, half-maximal inhibitory concentration: 270 nM
Compound 3: the middle estimate sits 1.4-fold (0.13 log units) below what was measured; measured number inside the range.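

In this assay, putting the group that holds selenium and a nitrile on the carbonyl carbon in place of the 1-bromoethyl group gives a 2.3-fold higher number from compound 1 to compound 3 (0.35 log units; beyond the scatter), so this place accepts a quite different group at a modest cost. Compound 3 still gives 270 nM without any bromine, which shows that the bromine of compound 1 is not needed for a value of this order. Compound 2, which carries no acyl group on its nitrogen and differs from compound 1 in more than one place, offers only a limit and not a number: the limit of > 80000 nM in this assay, at which 1 of the 3 values shown sits.

The selenium and the nitrile enter together, and the compounds shown do not separate their contributions. Going by these compounds, how a chlorine in place of the bromine, or a longer chain on this carbonyl carbon, would read also stays open.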